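This account rests on a few compounds, and the source may have more. Where it says the series, first, only, none or still open, it means among the compounds named here.

Measured in an ADME assay on CCRF-CEM cells (Homo sapiens) for cytotoxicity, read by MTT assay, with a stated time of 72 h; on this read-out lower numbers stand for higher toxicity in this test and higher numbers for lower toxicity in this test:
- compound 1 `CC(C)CC(=O)c1c(O)c(Cc2c(O)c(C(=O)CC(C)C)c(O)c(C(=O)CC(C)C)c2O)c(O)c(C(=O)CC(C)C)c1O`: "not determined" (no result reported)
- compound 2 `CC(=O)c1c(O)c(C(C)=O)c(O)c(C(c2c(O)c(C(C)=O)c(O)c(C(C)=O)c2O)C2CCCCC2)c1O`: 58900 nM
- compound 3 `CC(=O)c1c(O)c(C(C)=O)c(O)c(C(c2ccc(O)cc2)c2c(O)c(C(C)=O)c(O)c(C(C)=O)c2O)c1O`: "not determined" (no result reported)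

Compound 1 has no number to start from, since its entry reads "not determined" (no result reported). Compound 3 is in the same position, with "not determined" (no result reported). Going by the values given here, the series therefore rests on a single value, with compound 2 at 58900 nM, and no step between measured compounds is available.

Next in line is compound 4 `CC(C)CC(=O)c1c(O)c(C(=O)CC(C)C)c(O)c(C(c2ccccc2)c2c(O)c(C(=O)CC(C)C)c(O)c(C(=O)CC(C)C)c2O)c1O`. The change is phenyl in place of hydrogen on a saturated chain carbon bound to two aromatic carbons. The side chains of compound 1 stay as they are.

The size of the step from compound 1 cannot be stated, as one end of it is missing. Among the compounds with values here, the only anchor is compound 2 at 58900 nM, and it differs from compound 4 both in the carbonyl side chains and in the group on that saturated carbon. A moderate shift towards lower numbers than that of compound 2 in this assay is expected, though with low confidence, and a result within the scatter of it would not surprise. For compound 4 the value is estimated at 22000 nM, with an expected range of 6000 nM to 70000 nM.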

Compound 4, half-maximal cytotoxic concentration: 3150 nM
Compound 4: the middle estimate sits 7.0-fold (0.84 log units) above what was measured; the measured number lies below the stated range.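

No step can be read from compound 1 to compound 4, since in this assay compound 1 has no single number to compare. The compounds shown leave open how phenyl in place of hydrogen on that saturated chain carbon alters the read-out when nothing else changes. No supporting evidence bears on this result.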